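The source may hold more compounds than are shown below. What is called first, only, known or untested is meant among the compounds shown, and "the series" means these compounds.

Measured compounds:
compound 1 `O=C1c2sc(C#Cc3ccccc3)nc2CN1C1CC1`; compound 2 `O=C(C1CC1)N1CCc2nc(C#Cc3ccccc3)sc2C1`; compound 3 `O=C(C1CCCCC1)N1CCc2nc(C#Cc3ccccc3)sc2C1`.

In an assay on HEK293 cells for positive allosteric modulation of metabotropic glutamate receptor 5 (Homo sapiens), read by FLIPR, with a stated time of 1 h (on this read-out higher numbers stand for an effect only at larger amounts of compound and lower numbers for an effect already at smaller amounts), compound 1 gives only a limit, > 10000 nM. Compound 2 likewise gives only a limit, > 10000 nM. Compound 3 gives 167 nM. Compound 2 thus sits at the limit of > 10000 nM in this assay, at which 2 of the 3 values shown sit, together with compound 1 and apart from compound 3.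

Compound 4 `Cc1nc(C(=O)N2CCc3nc(C#Cc4ccccc4)sc3C2)cs1` differs from compound 2 by 2-methyl-1,3-thiazol-4-yl in place of cyclopropyl on a carbonyl carbon. Among the measured compounds shown here, the only measured step from compound 2 is an at least 59-fold lower number from compound 2 to compound 3 (1.77 log units; beyond the scatter), showing that a bulkier group on the same carbonyl carbon can carry the number well past the limit. The change to compound 4 also puts a bulkier group there, though an aromatic ring rather than a saturated one, so a step in the same direction is expected, likely smaller. Compound 4 is estimated at 600 nM (range 100 nM to 5000 nM), an expected step of an at least 16-fold lower number from compound 2 to compound 4 (1.22 log units; beyond the scatter).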

Compound 4, half-maximal effective concentration: 220 nM
Beside the measured number, compound 4's estimate is 2.7-fold (0.44 log units) above it, within the range that was stated.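

In this assay, the gain over cyclopropyl does not depend on a saturated ring: 2-methyl-1,3-thiazol-4-yl on the carbonyl carbon gives an at least 45-fold lower number from compound 2 to compound 4 (1.65 log units; beyond the scatter). Against cyclohexyl, the same group gives a 1.3-fold higher number from compound 3 to compound 4 (0.12 log units; within the scatter), so an aromatic ring with 2 hydrogen-bond acceptors and a saturated carbon ring cannot be told apart here. The value for compound 2 is a limit: the limit of > 10000 nM in this assay, at which 2 of the 4 values shown sit.

Still open, going by these compounds, is whether the methyl on the thiazole matters, and whether phenyl, pyridin-3-yl or a piperidine ring on the same carbonyl carbon would read alike.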